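The source may hold more compounds than are shown below. What is called first, only, known or untested is meant among the compounds shown, and "the series" means these compounds.

The series is followed in a functional assay on SGC-7901 cells (Homo sapiens) for antiproliferative activity, read by MTT assay, with a stated time of 48 h; a lower number here means a stronger inhibitor, a higher number a weaker inhibitor. In this assay compound 1 `Cc1ccc(-c2nnc(SCc3ccc(Cl)nc3)o2)cc1` gives 3.62 ug/mL and compound 2 `CCOc1ccc(-c2nnc(SCc3ccc(Cl)nc3)o2)cc1` gives 4.97 ug/mL, so these two numbers lie within the scatter of each other and neither stands apart. The open case is compound 3 `Clc1ccc(CSc2nnc(-c3ccccn3)o2)cn1`, which differs from compound 1 as pyridin-2-yl in place of 4-methylphenyl on an aromatic carbon of a five-membered aromatic ring with 2 nitrogen and 1 oxygen. For the measured compounds named here, only one measured step bears on this, and only loosely. That step, a 1.4-fold higher number from compound 1 to compound 2 (0.14 log units; within the scatter), is ethoxy in place of methyl on an aromatic carbon, and it leaves the six-membered aromatic ring of carbon only in place. Going by the values given here, no measured compound carries a hetero atom in that ring, so the data give no firm direction for the change. A step beyond the scatter is therefore not expected in this assay, though the range must stay wide. Compound 3 is estimated at 5 ug/mL, within an expected range from 2 ug/mL to 13 ug/mL. The expected step is a 1.4-fold higher number from compound 1 to compound 3 (0.14 log units; within the scatter).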

Compound 3, half-maximal inhibitory concentration: 12.6 ug/mL
Estimate against measurement, compound 3: 2.5-fold (0.40 log units) below; the range from low to high includes it.
By their numbers in this assay, from the lowest: compounds 1 and 2 (each within the scatter of the next); then compound 3.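

In this assay, this position on the aromatic carbon of the five-membered aromatic ring with 2 nitrogen and 1 oxygen proves sensitive to the identity of the ring it carries: pyridin-2-yl in place of 4-methylphenyl gives a 3.5-fold higher number from compound 1 to compound 3 (0.54 log units; beyond the scatter), so compound 3 is the weaker inhibitor of the pair. The earlier change, a 1.4-fold higher number from compound 1 to compound 2 (0.14 log units; within the scatter), altered only the group on a six-membered aromatic ring of carbon only and stayed within the scatter, so the new step is the first among these compounds to lie beyond it, though its size is modest. The step brings a ring nitrogen and removes the methyl group at once, the two cannot be separated from this single pair, and nothing measured on these compounds accounts for the loss.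

From the compounds shown here alone, whether plain phenyl would stay close to compound 1 or fall toward compound 3 remains open, and that comparison would show how much of the step belongs to the methyl group. Also open, going by these compounds, is whether pyridin-3-yl or pyridin-4-yl, with the ring nitrogen placed elsewhere, would give the same higher number.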